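Isopropyl to chloromethyl on a carbonyl carbon

The source may hold more compounds than are shown below. What is called first, only, known or untested is meant among the compounds shown, and "the series" means these compounds.

In a functional assay on A-375 cells (Homo sapiens) for cytotoxicity, read by MTT assay (on this read-out higher numbers stand for weaker inhibition and lower numbers for stronger inhibition), three compounds built on one shared core have been measured. Compound 1 (`COc1ccc(/C=C/C(=O)c2ccc(OC)c3c2OC(C)(C)C=C3)cc1OCCO`), with 2-hydroxyethyl on an oxygen on an aromatic ring, gives 9600 nM in this test. Compound 2 (`CCCCC(=O)Oc1cc(/C=C/C(=O)c2ccc(OC)c3c2OC(C)(C)C=C3)ccc1OC`), with butylcarbonyl on that oxygen, gives 220 nM and compound 3 (`COc1ccc(/C=C/C(=O)c2ccc(OC)c3c2OC(C)(C)C=C3)cc1OC(=O)C(C)C`), with isopropylcarbonyl there, gives 310 nM on the same read-out. Compound 3 therefore lies far under compound 1 and level with compound 2 within the scatter.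

Compound 4 (`COc1ccc(/C=C/C(=O)c2ccc(OC)c3c2OC(C)(C)C=C3)cc1OC(=O)CCl`) follows from compound 3 by one change (chloromethyl in place of isopropyl on a carbonyl carbon), chloromethyl in place of isopropyl on a carbonyl carbon. The two large steps (a 44-fold lower number from compound 1 to compound 2 (1.64 log units; beyond the scatter) and a 31-fold lower number from compound 1 to compound 3 (1.49 log units; beyond the scatter)) both swap 2-hydroxyethyl for a carbonyl-bearing group, and compound 4 keeps a carbonyl there, so they set its general level rather than this step. The step that bears directly is the exchange on the same carbonyl carbon (a 1.4-fold higher number from compound 2 to compound 3 (0.15 log units; within the scatter)), which stays within the scatter. Going by the values given here, no measured compound carries chlorine, so this one precedent is thin, and no step beyond the scatter is expected in this assay. The estimated step is small (a 1.1-fold lower number from compound 3 to compound 4 (0.04 log units; within the scatter)). Compound 4 is expected at 280 nM in this test, within an estimated range of 90 nM to 900 nM overall.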

Compound 4, half-maximal inhibitory concentration: 450 nM
Beside the measured number, compound 4's estimate is 1.6-fold (0.21 log units) below it; the range from low to high includes it.
By their numbers in this assay, from the lowest: compounds 2, 3 and 4 (each within the scatter of the next, the first and the last beyond it); then compound 1.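

In this assay, going by these compounds alone, the exchange of isopropyl for chloromethyl on the carbonyl carbon (a 1.5-fold higher number from compound 3 to compound 4 (0.16 log units; within the scatter)) shows that this position accepts a chlorine-bearing group without a change beyond the scatter, whereas the exchange of propyl for chloro on the saturated chain carbon bound to the carbonyl carbon (a 2.0-fold higher number from compound 2 to compound 4 (0.31 log units; beyond the scatter)) gives the first step among the carbonyl-bearing compounds to pass the scatter, and only modestly. The large step away from 2-hydroxyethyl on the oxygen on an aromatic ring also holds for this third carbonyl-bearing group (a 21-fold lower number from compound 1 to compound 4 (1.33 log units; beyond the scatter)), so butylcarbonyl, isopropylcarbonyl and (chloromethyl)carbonyl all lie far from 2-hydroxyethyl on this read-out. No measured evidence bears on what lies behind these steps.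

As far as these compounds go, whether the chlorine itself contributes anything remains open, since a plain methyl or a bromomethyl on the same carbonyl carbon would be needed to separate it from the size of the group. Also open, from the compounds shown here alone, is how an amine or a carboxylic acid at the end of a longer chain on this carbonyl carbon, or a free hydroxyl on the oxygen itself, would stand in this assay.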